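The compounds below may be only part of what the source reports. "The series", "measured", "known", "first", "only" and "open" are said of these compounds alone.

Compound 1 `COc1cc2c(Oc3ccc(NC(=O)c4nn(-c5ccccc5C(F)(F)F)c(=O)cc4C)cc3F)ccnc2cc1OCCCN1CCC(C)CC1` is one of two compounds that have been measured in a functional assay on A549 cells (Homo sapiens) for inhibition, read by MTT assay, with a stated time of 72 h (a lower number here means a stronger inhibitor, a higher number a weaker inhibitor), and in that assay compound 1 gives 160 nM. Compound 2 `COc1cc2c(Oc3ccc(NC(=O)c4nn(-c5ccccc5C(F)(F)F)c(=O)cc4C)cc3F)ccnc2cc1OCCCN1CCN(C)CC1`, which carries a different amine at the end of the chain, gives 170 nM in this assay; the step of a 1.1-fold higher number from compound 1 to compound 2 (0.03 log units; within the scatter) shows that the two compounds cannot be told apart. Of the two numbers shown, that of compound 1 is the lower, but the gap to compound 2 lies within the scatter.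

Compound 3 `COc1cc2c(Oc3ccc(NC(=O)c4nn(-c5ccc(Cl)cc5Cl)c(=O)cc4C)cc3F)ccnc2cc1OCCCN1CCC(C)CC1` has not yet been measured. It differs from compound 1 at another place: 2,4-dichlorophenyl in place of 2-(trifluoromethyl)phenyl on an aromatic nitrogen. Going by the values given here, the single measured step concerns only the amine on the chain and leaves the aryl group on the ring nitrogen untouched, so no measured step bears on this change. The expectation for compound 3 therefore rests on compound 1 alone, without a direction and with a wide range; the step is estimated as a 1.3-fold higher number from compound 1 to compound 3 (0.10 log units; within the scatter). The number for compound 3 in this assay is estimated at 200 nM, with a range from 60 nM to 700 nM.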

Compound 3, half-maximal inhibitory concentration: 200 nM
For compound 3 middle estimate and measured number coincide at the digits printed; low and high end bracket the measured number.
By their numbers in this assay, from the lowest: compounds 1, 2 and 3 (each within the scatter of the next).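

Going by these compounds alone, compound 3 gives the first measured look at the aryl group on the aromatic nitrogen, and in this assay replacing 2-(trifluoromethyl)phenyl with 2,4-dichlorophenyl gives a 1.3-fold higher number from compound 1 to compound 3 (0.10 log units; within the scatter) and thus no change that can be told from the scatter. The earlier pair showed this only for the amine at the end of the chain, whereas this pair shows that the position on the ring nitrogen also accepts two different substituted phenyl groups, one of 10 heavy atoms with three fluorine and one of 8 heavy atoms with two chlorine, without a readable difference in this assay. No measurement at hand explains this outcome.

The compounds shown leave open whether the position stays as tolerant with an unsubstituted phenyl, a 4-methoxyphenyl, a pyridyl ring or a small alkyl group such as methyl on the ring nitrogen, since both aryl groups tested so far carry a substituent beside the ring bond's carbon in the same place. They also leave open whether 2,4-dichlorophenyl behaves the same alongside 4-methylpiperazin-1-yl or a morpholine at the end of the chain.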